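The source may hold more compounds than are shown below. What is called first, only, known or untested is meant among the compounds shown, and "the series" means these compounds.

Measured compounds:
- compound 1 `[O-]/[N+](=C\c1cn(-c2ccc(C(F)(F)F)cc2)nn1)Cc1ccccc1`; in a functional assay on A549 cells (Homo sapiens) for inhibition, read by MTT assay, with a stated time of 24 h (on this read-out lower numbers stand for stronger inhibition and higher numbers for weaker inhibition), compound 1 gives > 100000 nM, which is a limit of the assay.
- compound 2 `CC(C)(C)/[N+]([O-])=C/c1cn(-c2ccccc2)nn1`; in this assay compound 2 gives 17400 nM.
- compound 3 `COc1ccc(-n2cc(/C=[N+](\[O-])C(C)(C)C)nn2)cc1`; in this assay compound 3 gives 23700 nM.

Compound 3 holds the highest of the two numbers that were read as numbers, and compound 2 is its nearest neighbour: the step of a 1.4-fold higher number from compound 2 to compound 3 (0.13 log units; within the scatter) lies within the scatter, so the two cannot be ordered. Compound 1 sits at the limit of > 100000 nM in this assay, at which 1 of the 3 values shown sits, and contributes no number.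

Compound 4 `CC(C)(C)/[N+]([O-])=C/c1cn(-c2ccc(C(F)(F)F)cc2)nn1` differs from compound 3 by trifluoromethyl in place of methoxy on an aromatic carbon. Among the measured compounds shown here, the one measured step on this ring, a 1.4-fold higher number from compound 2 to compound 3 (0.13 log units; within the scatter), was small, which gives little ground for a large change here. For the measured compounds named here, compound 1 also carries a trifluoromethyl on its aromatic ring, but it differs from compound 4 in the group on the nitrone nitrogen as well, and no step between them is available; its value shows only a limit.

Compound 4 is therefore expected to give about 30000 nM in this assay, within a range of 10000 nM to 100000 nM, the estimated step being a 1.3-fold higher number from compound 3 to compound 4 (0.10 log units; within the scatter).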

Compound 4, half-maximal inhibitory concentration: 43600 nM
Compound 4: the middle estimate sits 1.5-fold (0.16 log units) below what was measured; low and high end bracket the measured number.
By their numbers in this assay, from the lowest: compounds 2, 3 and 4 (each within the scatter of the next, the first and the last beyond it). At a limit, above all of these: compound 1.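

With trifluoromethyl on the aromatic ring, the shared core gives a 2.5-fold higher number from compound 2 to compound 4 (0.40 log units; beyond the scatter) in this assay and so moves clearly away from the hydrogen compound at this place, which the methoxy step had not done. Against methoxy itself, trifluoromethyl gives a 1.8-fold higher number from compound 3 to compound 4 (0.26 log units; within the scatter) and so cannot be ordered. With trifluoromethyl held fixed, the nitrogen substituent also matters, as tert-butyl in place of benzyl gives an at least 2.2-fold lower number from compound 1 to compound 4 (0.36 log units; beyond the scatter) and this is the only step shown at that nitrogen, but compound 1 stands at a limit and not at a number: the limit of > 100000 nM in this assay, at which 1 of the 4 values shown sits.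

From the compounds shown here alone, the true size of that nitrogen step therefore stays open, as does how a longer alkyl chain on the nitrogen would read. Going by these compounds, it is also open how an amine or a carboxylic acid would read on the aromatic carbon.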